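From compound 3 to compound 4: same atoms, rearranged

The source may report more compounds than this note shows. Statements on the series, on what has been measured and on what is new or still open speak of the compounds shown alone.

Measured in an ADME assay on microsomes from liver (Homo sapiens) for metabolic stability, read by LC-MS, tested at 1 uM; on this read-out higher numbers stand for fast clearance and lower numbers for slow clearance:
- compound 1 `NC(=O)C1CCN(Cc2ccc([C@H]3CC[C@]4(CC3)OOC3(O4)C4CC5CC(C4)CC3C5)cc2)CC1`: 10 mL.min-1.g-1
- compound 2 `OC1(COc2ccc([C@H]3CC[C@]4(CC3)OOC3(O4)C4CC5CC(C4)CC3C5)cc2)CCNCC1`: 16 mL.min-1.g-1
- compound 3 `c1cc([C@H]2CC[C@]3(CC2)OOC2(O3)C3CC4CC(C3)CC2C4)ccc1OCC1CCNCC1`: < 7 mL.min-1.g-1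

Compound 3 stands at < 7 mL.min-1.g-1, which is a limit of the assay and not a number. Compound 4 `N[C@H]1CC[C@@H](Oc2ccc([C@H]3CC[C@]4(CC3)OOC3(O4)C4CC5CC(C4)CC3C5)cc2)CC1` has the same atoms, joined differently, with 4-aminocyclohexyl in place of (piperidin-4-yl)methyl on an oxygen on an aromatic ring. The nearest guides are an at least 1.4-fold lower number from compound 1 to compound 3 (0.15 log units; that floor lies within the scatter) and an at least 2.2-fold lower number from compound 2 to compound 3 (0.35 log units; beyond the scatter). Neither makes this exchange, so no step beyond the scatter is expected in this assay. The expected step is an at least 1.1-fold higher number from compound 3 to compound 4 (0.05 log units; that floor lies within the scatter). Compound 4 is estimated at 8 mL.min-1.g-1, with an expected range from 4 mL.min-1.g-1 to 16 mL.min-1.g-1.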

Compound 4, intrinsic clearance in microsomes in the liver assay: < 7 mL.min-1.g-1
Compound 4 gave a limit, no number (the forecaster's own chance of this, stated with the estimate: 40%); at least 1.1-fold (0.05 log units) between middle value and limit.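

In the liver assay, compound 3 stands at < 7 mL.min-1.g-1, which is a limit of the assay and not a number. In the liver assay, compound 4 stands at < 7 mL.min-1.g-1, which is also a limit of the assay and not a number. The two sit at the same limit, so the step between them cannot be read: the limit of < 7 mL.min-1.g-1 in the liver assay, at which 2 of the 4 values shown sit.

A ring of carbon only carrying the amine can therefore take the place of the piperidine ring without leaving that limit, and the liver assay gives an at least 2.2-fold lower number from compound 2 to compound 4 (0.35 log units; beyond the scatter) and an at least 1.4-fold lower number from compound 1 to compound 4 (0.15 log units; that floor lies within the scatter). In a physicochemical assay for solubility, read by nephelometry, measured as kinetic solubility, with a stated time of 30 min (on this read-out higher numbers stand for higher solubility and lower numbers for lower solubility), compound 3 gives 12.5 ug/mL and compound 4 gives 25 ug/mL. In the physicochemical assay, the same exchange gives a 2.0-fold higher number from compound 3 to compound 4 (0.30 log units; within the scatter).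

Going by these compounds, the numbers behind the two limits stay open. So does whether a carboxylic acid or a longer chain ending in an amine on this oxygen would also stay at the limit.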